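A few compounds are considered here, and "the series" means these few. Any claim that something is new, unique, unknown or untested is made for them only; others in the source may bear on it.

Compound 1 `COC1=C(C)C(=O)/C(=C(O)/C=C/c2ccc(Br)cc2)C(=O)C1(C)C` gives 1.9 ug/mL in a functional assay on KB cells (Homo sapiens) for cytotoxicity; a higher number here means that more compound is needed for the effect, a lower number that less compound is needed.
Compound 2 `COC1=C(C)C(=O)/C(=C(O)/C=C/c2cccc(OC)c2)C(=O)C1(C)C` gives 2.4 ug/mL in this assay.

Going by the values given here, compound 2 has the highest of the two numbers measured so far, and its nearest neighbour is compound 1, separated by a 1.3-fold higher number from compound 1 to compound 2 (0.10 log units; within the scatter). The two compounds therefore cannot be told apart on this measurement.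

Compound 3 `COC1=C(C)C(=O)/C(=C(O)/C=C/c2c(C)cccc2C)C(=O)C1(C)C` is the unmeasured compound. It differs from compound 2 in one place: 2,6-dimethylphenyl in place of 3-methoxyphenyl on a double-bonded chain carbon bound to a double-bonded chain carbon.

Among the compounds with values here, only one measured step touches the same position, the step of a 1.3-fold higher number from compound 1 to compound 2 (0.10 log units; within the scatter), in which one aryl group replaced another without moving the number beyond the scatter. That step gives no sign that swapping the aryl group at this place shifts the result, so compound 3 is expected to stay close to compound 2, with a step of no change at the digits printed from compound 2 to compound 3 (within the scatter) that is not expected to exceed the scatter. Compound 3 is accordingly estimated at 2.4 ug/mL, within a range from 1 ug/mL to 6 ug/mL.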

Compound 3, concentration for half-maximal effect: 2.1 ug/mL
For compound 3 the middle estimate is 1.1-fold (0.06 log units) above the measured one; low and high end bracket the measured number.
By their numbers in this assay, from the lowest: compounds 1, 3 and 2 (each within the scatter of the next).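

In this assay the 2,6-dimethylphenyl group gives a 1.1-fold lower number from compound 2 to compound 3 (0.06 log units; within the scatter) and a 1.1-fold higher number from compound 1 to compound 3 (0.04 log units; within the scatter) at this place, on a double-bonded chain carbon bound to a double-bonded chain carbon, so the three aryl groups shown cannot be told apart. The change also removes the hydrogen-bond acceptor of 3-methoxyphenyl and puts an all-carbon group of equal heavy-atom count in its place, and the number stays within the scatter, so this read-out does not depend on that oxygen in this series. Nothing available gives a reason for this lack of response.

Every group shown is a phenyl ring carrying small substituents, so it remains open whether this insensitivity would hold for a phenyl ring bearing an amine or a carboxylic acid. As far as these compounds go, a saturated ring such as cyclohexyl at the same place is equally open.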